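This account rests on a few compounds, and the source may have more. Where it says the series, first, only, none or still open, it means among the compounds named here.

Compound 1 `CC1(C)[C@H]2CC[C@]1(C)N(Cc1cn(-c3ccc(C#N)cc3)nn1)C(=O)C2` gives 380 nM in a functional assay on OVCAR-3 cells (Homo sapiens) for inhibition, read by MTT assay, with a stated time of 24 h; on this read-out higher numbers stand for weaker inhibition and lower numbers for stronger inhibition
Compound 2 `CC1(C)[C@H]2CC[C@]1(C)N(Cc1cn(-c3cccc(C#N)c3)nn1)C(=O)C2` gives 230 nM in this assay

Compound 1 has a single measured neighbour, and the two sit close: the data show a 1.7-fold lower number from compound 1 to compound 2 (0.22 log units; within the scatter) and no wider gap. Compound 3 `CC1(C)[C@H]2CC[C@]1(C)N(Cc1cn(-c3ccc(F)cc3)nn1)C(=O)C2` has not yet been measured in this assay and differs from compound 1 at the nitrile. The count of that difference reads fluoro in place of cyano on an aromatic carbon and, in words, it is fluoro in place of cyano on an aromatic carbon, para to a large group, which makes 4-cyanophenyl to 4-fluorophenyl.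

Within the data shown here, only one measured step bears on this, and only loosely. The step of a 1.7-fold lower number from compound 1 to compound 2 (0.22 log units; within the scatter) changes the position of the cyano group but does not replace it. Among the measured compounds shown here, no measured compound carries fluoro, so the data offer no direction for the change. Accordingly, a 1.1-fold lower number from compound 1 to compound 3 (0.04 log units; within the scatter) is the expected step in this assay and nothing beyond the scatter is anticipated. Compound 3 is expected at 350 nM within an estimated range from 120 nM to 1000 nM on this reasoning.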

Compound 3, half-maximal inhibitory concentration: 200 nM
Estimate against measurement, compound 3: 1.8-fold (0.24 log units) above; low and high end bracket the measured number.
By their numbers in this assay, from the lowest: compounds 3, 2 and 1 (each within the scatter of the next).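

In this assay, replacing the nitrile outright with fluoro, on an aromatic carbon para to a large group, gives a 1.9-fold lower number from compound 1 to compound 3 (0.28 log units; within the scatter), whereas the earlier comparison only changed where the cyano group sat. Set against the other nitrile-bearing compound, the same fluoro compound gives a 1.2-fold lower number from compound 2 to compound 3 (0.06 log units; within the scatter), so all three compounds stand together on this read-out, and neither the location of the nitrile nor its presence separates them. The cyano group is therefore not required for a number in this range: fluoro, with one heavy atom in place of two and no counted hydrogen-bond acceptor in place of one, serves equally well here, although nothing available explains why.

Whether an amine, a carboxylic acid, a methoxy group or a longer chain on this aromatic ring would move the number beyond the scatter remains open, since the two substituents shown cover only a narrow range of groups. All three compounds also share the core of compound 1, so they cannot tell whether the same indifference to the substituent would persist if that core were altered.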